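Methoxy for trifluoromethyl in a cytotoxicity series

A few compounds are considered here, and "the series" means these few. Any claim that something is new, unique, unknown or untested is made for them only; others in the source may bear on it.

Of the compounds shown here, three on a shared core have been measured in a functional assay on B16 cells (Mus musculus) for cytotoxicity, read by MTT assay, with a stated time of 48 h; a lower number here means a stronger inhibitor, a higher number a weaker inhibitor. Compound 1 `COc1ccc(-c2cn(C[C@H]3COC(C)(C)O3)nn2)cc1` gives > 100000 nM, which is a limit of the assay and not a number. Compound 2 `Cc1ccc(-c2cn(CCCO)nn2)cc1` likewise gives > 100000 nM, a limit. Compound 3 `OCCCn1cc(-c2ccc(C(F)(F)F)cc2)nn1` stands at > 100000 nM, again a limit. For the measured compounds named here, the single step between measured compounds that differ in one place, a step that the two limits leave unreadable from compound 2 to compound 3, cannot be read; both of its ends are limits, and the limit of > 100000 nM in this assay, at which 3 of the 3 values shown sit, holds every value shown so far.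

Compound 4 `COc1ccc(-c2cn(CCCO)nn2)cc1` is not yet measured. It differs from compound 3 by methoxy in place of trifluoromethyl on an aromatic carbon. Going by the values given here, no measured step bears on this change directly: the only step available exchanged methyl for trifluoromethyl on the same aromatic carbon, and its size is unreadable. With all three values sitting at the limit, the expected step is a step that the limit leaves unreadable from compound 3 to compound 4, and no change beyond the scatter is expected. Compound 4 is therefore estimated at 200000 nM in this assay, with a range from 60000 nM to 1000000 nM, and the most likely outcome expected for compound 4 is that this assay again reports only a limit.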

Compound 4, half-maximal inhibitory concentration: > 100000 nM
Compound 4 was reported as a limit; the forecaster's own chance of this, stated with the estimate: 85%; the middle value is on the limit's open side.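

In this assay compound 4 gives > 100000 nM, a limit of the assay and not a number. Its steps from compound 1, compound 2 and compound 3 therefore cannot be read: the limit of > 100000 nM in this assay, at which 4 of the 4 values shown sit.

The compounds shown leave open whether any group on the shared core gives a readable value in this assay, and how methoxy, methyl and trifluoromethyl compare.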